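Swapping a basic amine for an ether on the benzoyl ring

The source may hold more compounds than are shown below. What is called first, only, known or untested is meant among the compounds shown, and "the series" means these compounds.

Compound 1 `Cc1c(C(=O)c2cccc(CN(C)C)c2)oc2cc(-c3ccccc3)cc(O)c12` is the benchmark of this set. In a functional assay on WI-38 VA13 cells (Homo sapiens) for cytotoxicity (a higher number here means that more compound is needed for the effect, a lower number that less compound is needed), compound 1 gives 0.09 ug/mL, the lowest of the two numbers available. Compound 2 `COc1ccc(C(=O)c2oc3cc(-c4ccccc4)cc(O)c3c2C)cc1OC`, which carries two methoxy groups on the benzoyl ring instead of the aminomethyl group, gives 0.45 ug/mL in this assay, and the gap between compound 1 and compound 2 lies beyond the usual scatter. Compound 3 `CCc1ccc(C(=O)c2oc3cc(-c4ccccc4)cc(O)c3c2C)cc1`, with an ethyl group on that ring, reaches only the limit of this assay, (the limit of > 4 ug/mL in this assay, at which 1 of the 3 values shown sits), so for compound 3 the value > 4 ug/mL is a limit and not a number.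

Compound 4 `Cc1c(C(=O)c2cccc(OC(C)C)c2)oc2cc(-c3ccccc3)cc(O)c12` keeps the shared core and the benzoyl ring but changes one substituent. isopropoxy in place of (dimethylamino)methyl on an aromatic carbon

For the measured compounds named here, with the basic amine gone, compound 4 resembles compound 2 more than compound 1 in the nature of its substituent, though no measured pair tells exactly what an isopropoxy group does here. The step from compound 1 to compound 4 is therefore expected to raise the number by a 6.7-fold higher number from compound 1 to compound 4 (0.82 log units; beyond the scatter), in the direction of compound 2 rather than of compound 3. Compound 4 is estimated to give 0.6 ug/mL in this assay, within a range from 0.15 ug/mL to 2.5 ug/mL.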

Compound 4, half-maximal effective concentration: 0.35 ug/mL
Beside the measured number, compound 4's estimate is 1.7-fold (0.23 log units) above it, and the stated range covers the measured number.
By their numbers in this assay, from the lowest: compound 1; then compounds 4 and 2 (each within the scatter of the next). At a limit, above all of these: compound 3.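

For the compounds shown here, compound 4 gives the first step in this set that isolates a single change to compound 1, since compounds 2 and 3 are not linked to it by any one-place step. In this assay, placing isopropoxy in place of (dimethylamino)methyl on an aromatic carbon, meta to a large group, gives a 3.9-fold higher number from compound 1 to compound 4 (0.59 log units; beyond the scatter), a modest change that lies beyond the scatter. The two groups have the same counts of heavy atoms, hydrogen-bond donors and hydrogen-bond acceptors, and the exchange replaces nitrogen with oxygen, but no measurement shown bears on what lies behind the step.

The compounds shown leave open how other groups would behave at this position, such as a primary amine, a morpholine, a carboxylic acid or a longer ether chain, so a single exchange cannot show whether the nitrogen itself is what matters. They also leave open whether the same exchange would give a step of similar size elsewhere on that ring.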